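Replacing an aryl group: from compound 2 to compound 3

This account rests on a few compounds, and the source may have more. Where it says the series, first, only, none or still open, it means among the compounds named here.

Compound 1 `O=[N+]([O-])c1c(CS(=O)(=O)c2ccccc2)nc2c(-c3ccccc3CO)cc(Cl)cn12` – 88000 nM
Compound 2 `O=[N+]([O-])c1c(CS(=O)(=O)c2ccccc2)nc2c(-c3ccccc3C(F)(F)F)cc(Cl)cn12` – 22700 nM

Within the data shown here, in an ADME assay on HepG2 cells (Homo sapiens) for cytotoxicity, read by MTT assay, with a stated time of 72 h (on this read-out lower numbers stand for higher toxicity in this test and higher numbers for lower toxicity in this test), compound 2 gives 22700 nM, the lower of the two numbers measured so far. Compound 3 `O=[N+]([O-])c1c(CS(=O)(=O)c2ccccc2)nc2c(-c3ccco3)cc(Cl)cn12` has not yet been measured. It differs from compound 2 by furan-2-yl in place of 2-(trifluoromethyl)phenyl on an aromatic carbon. Among the measured compounds shown here, only one measured step bears on this change, and it bears only indirectly. This is a 3.9-fold lower number from compound 1 to compound 2 (0.59 log units; beyond the scatter), which altered a single group on the aryl substituent that compound 3 loses. For the measured compounds named here, no measured step replaces that whole substituent, so the direction is uncertain. A modest rise of similar size is expected, and the expected step is a 1.8-fold higher number from compound 2 to compound 3 (0.25 log units; within the scatter). The estimate for compound 3 is 40000 nM, with an expected range from 14000 nM to 110000 nM.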

Compound 3, half-maximal cytotoxic concentration: > 3900 nM
Compound 3 ended at the assay's limit (the forecaster's own chance of this, stated with the estimate: 15%); the middle value is on the limit's open side.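

The steps from compound 1 and from compound 2 to compound 3 cannot be read, because the result for compound 3 is a limit and not a number: the limit of > 3900 nM in this assay, at which 1 of the 3 values shown sits.

The compounds shown leave open whether furan-2-yl in place of 2-(trifluoromethyl)phenyl raises or lowers the number in this assay.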